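The source may report more compounds than this note shows. Statements on the series, on what has been measured and on what is new or still open speak of the compounds shown alone.

In a functional assay on SW480 cells (Homo sapiens) for antiproliferative activity, read by MTT assay, with a stated time of 48 h (a lower number here means a stronger inhibitor, a higher number a weaker inhibitor), three compounds sharing one core have been measured, and they differ only on a saturated chain carbon bound to a double-bonded ring carbon. Compound 1 `COC/C1=C/C[C@](C)(CCC=C(C)C)/C=C/[C@@H](OC(=O)C=C(C)C)[C@](C)(O)/C=C/C1=O`, with methoxy there, gives 3850 nM. Compound 2 `CC(C)=CCC[C@]1(C)/C=C/[C@@H](OC(=O)C=C(C)C)[C@](C)(O)/C=C/C(=O)/C(CCl)=C\C1`, with chloro, gives 390 nM. Compound 3 `CC(C)=CCC[C@]1(C)/C=C/[C@@H](OC(=O)C=C(C)C)[C@](C)(O)/C=C/C(=O)/C(C[Si](C)(C)C(C)(C)C)=C\C1`, with a silicon-bearing group, gives 3350 nM. Compound 3 thus shares the high end of the numbers with compound 1, as a 1.1-fold lower number from compound 1 to compound 3 (0.06 log units; within the scatter) shows, while an 8.6-fold higher number from compound 2 to compound 3 (0.93 log units; beyond the scatter) separates it from the remaining compound.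

Compound 4 `CC(C)=CCC[C@]1(C)/C=C/[C@@H](OC(=O)C=C(C)C)[C@](C)(O)/C=C/C(=O)/C(COC(=O)c2ccc([N+](=O)[O-])cc2)=C\C1` changes the same carbon again, with ((4-nitrophenyl)carbonyl)oxy entering: a group of 12 heavy atoms (7 carbon, 1 nitrogen, 4 oxygen; one six-membered aromatic ring of carbon only) in place of a group of 7 heavy atoms (6 carbon, 1 silicon; no ring), on a saturated chain carbon bound to a double-bonded ring carbon. The steps at this carbon bear on the change, and the largest of them is a 9.9-fold lower number from compound 1 to compound 2 (0.99 log units; beyond the scatter). No measured group at this carbon holds an aromatic ring, so the direction is uncertain. Since compound 3 already lies at the high end, a modest move towards lower numbers is expected in this assay. The estimated change is a 2.2-fold lower number from compound 3 to compound 4 (0.35 log units; beyond the scatter). Compound 4 is expected at 1500 nM, with an estimated range of 400 nM to 5000 nM.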

Compound 4, half-maximal inhibitory concentration: 570 nM
Estimate against measurement, compound 4: 2.6-fold (0.42 log units) above; low and high end bracket the measured number.
By their numbers in this assay, from the lowest: compounds 2 and 4 (each within the scatter of the next); then compounds 3 and 1 (each within the scatter of the next).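

In this assay, among these compounds, this carbon carries a group with an aromatic ring for the first time, and that group gives a 5.9-fold lower number from compound 3 to compound 4 (0.77 log units; beyond the scatter). Keeping the oxygen on this carbon but putting (4-nitrophenyl)carbonyl in place of methyl gives a 6.8-fold lower number from compound 1 to compound 4 (0.83 log units; beyond the scatter), so the oxygen alone does not fix the number; what is attached to it matters. Chloro is also no longer alone at the low end, as a 1.5-fold higher number from compound 2 to compound 4 (0.16 log units; within the scatter) lies within the scatter, although no measurement here explains these results.

As far as these compounds go, it remains open whether the ring, the nitro group or the carbonyl accounts for the change. A plain benzoyl group or an acetyl group on the same oxygen would help separate these parts, while an amine on this carbon would test a different kind of group.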